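Amide Variation on a Shared Core: Cytotoxicity Notes

The source may hold more compounds than are shown below. What is called first, only, known or untested is meant among the compounds shown, and "the series" means these compounds.

Measured so far:
Compound 1 `COc1ccc(-c2cnc(NC(=O)c3ccccn3)n2C)cc1` gives > 100000 nM in a toxicity assay on THP-1 cells (Homo sapiens) for inhibition; on this read-out lower numbers stand for higher toxicity in this test and higher numbers for lower toxicity in this test; this is a limit of the assay, not a number.
Compound 2 `COc1ccc(-c2cnc(NC(=O)CCc3ccccc3)n2C)cc1` gives > 100000 nM in this assay; again a limit.
Compound 3 `COc1ccc(-c2cnc(NC(=O)c3ccc(F)cc3)n2C)cc1` gives >= 50000 nM in this assay; also a limit.

Compound 3 thus stands at a limit, as do the two other values: the limit of > 100000 nM in this assay, at which 2 of the 3 values shown sit, (the limit of >= 50000 nM in this assay, at which 1 of the 3 values shown sits). No readable step exists in the series; a step that the two limits leave unreadable from compound 1 to compound 3 and a step that the two limits leave unreadable from compound 2 to compound 3 cannot be sized. Compound 4 `CCCC(=O)Nc1ncc(-c2ccc(OC)cc2)n1C` is not yet measured. The change is propyl in place of 4-fluorophenyl on a carbonyl carbon. With every step unreadable, no movement beyond the scatter is expected, and compound 4 is estimated to sit again at a limit in this assay, about 100000 nM (range 50000 nM to 200000 nM). The expected step is a step that the limit leaves unreadable from compound 3 to compound 4.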

Compound 4, half-maximal cytotoxic concentration: > 100000 nM
Compound 4: no number, only a limit (the forecaster's own chance of this, stated with the estimate: 85%); the middle value sits exactly at the limit.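

Compound 4 gives > 100000 nM in this assay, a limit of the assay. With compound 1, compound 2 and compound 3 also at limits, no step among these four compounds can be read. The compounds shown leave open whether any amide variation on the shared core gives a measurable cytotoxic concentration.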